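This account rests on a few compounds, and the source may have more. Where it says the series, first, only, none or still open, it means among the compounds named here.

Measured compounds:
compound 1 `CCS(=O)(=O)Nc1cc(-c2ccc3ncnc(Nc4ccc(F)cc4F)c3c2)cnc1OC` — 4710 nM
compound 2 `CCS(=O)(=O)Nc1cc(-c2ccc3ncnc(Nc4ccc(OC)cc4)c3c2)cnc1OC` — 3580 nM

In a functional assay on A549 cells (Homo sapiens) for cytotoxicity, read by sulforhodamine B assay, with a stated time of 72 h (on this read-out higher numbers stand for weaker inhibition and lower numbers for stronger inhibition), compound 2 gives 3580 nM, and compound 1 gives 4710 nM; the two stand within the scatter of each other, since the step of a 1.3-fold lower number from compound 1 to compound 2 (0.12 log units; within the scatter) is small. Compound 3 `CCS(=O)(=O)Nc1cc(-c2ccc3ncnc(Nc4ccc(F)c(C(=O)OC)c4)c3c2)cnc1OC` differs from compound 2 by 4-fluoro-3-(methoxycarbonyl)phenyl in place of 4-methoxyphenyl on a nitrogen on an aromatic ring. Among the compounds with values here, the only measured step that touches this phenyl group, a 1.3-fold lower number from compound 1 to compound 2 (0.12 log units; within the scatter), moved the number within the scatter, so for compound 3 no shift beyond the scatter in this assay is expected, with a 1.1-fold higher number from compound 2 to compound 3 (0.03 log units; within the scatter). Compound 3 is therefore estimated at 3800 nM, within a range from 1500 nM to 9500 nM.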

Compound 3, half-maximal inhibitory concentration: 3420 nM
Compound 3: the middle estimate sits 1.1-fold (0.05 log units) above what was measured; the range from low to high includes it.
By their numbers in this assay, from the lowest: compounds 3, 2 and 1 (each within the scatter of the next).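

In this assay the nitrogen on an aromatic ring now carries a third substituted phenyl group, 4-fluoro-3-(methoxycarbonyl)phenyl, which gives a 1.0-fold lower number from compound 2 to compound 3 (0.02 log units; within the scatter) and a 1.4-fold lower number from compound 1 to compound 3 (0.14 log units; within the scatter). Both steps lie within the scatter, so a methoxycarbonyl group can stand on this phenyl group, together with a fluorine, without a readable change among these three compounds. No evidence is available that bears on this result. The compounds shown leave open whether an amine, a carboxylic acid or a longer chain in place of the methoxycarbonyl group would move the number beyond the scatter.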